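Thioether in place of selenoether on the shared core

This account rests on a few compounds, and the source may have more. Where it says the series, first, only, none or still open, it means among the compounds named here.

Within the data shown here, compound 2 `C[Se]c1nc(NCc2ccccc2)c2ccccc2n1` holds the only number: in an ADME assay on BEAS-2B cells (Homo sapiens) for cytotoxicity, read by MTT assay, with a stated time of 72 h (on this read-out lower numbers stand for stronger inhibition of growth and higher numbers for weaker inhibition of growth), compound 2 gives 37000 nM. Compound 1 `Sc1nc(NCc2ccccc2)c2ccccc2n1` reports no number in this assay but a limit, > 100000 nM, the assay limit (the limit of > 100000 nM in this assay, at which 1 of the 2 values shown sits). Among the measured compounds shown here, the single measured step, an at least 2.7-fold lower number from compound 1 to compound 2 (0.43 log units; beyond the scatter), exchanges one sulfur atom for the carbon-selenium group at the same aromatic carbon. Compound 3 `CSc1nc(NCc2ccccc2)c2ccccc2n1` carries the change (a group of 2 heavy atoms (1 carbon, 1 sulfur; no ring) in place of a group of 2 heavy atoms (1 carbon, 1 selenium; no ring), on an aromatic carbon). That measured step bears only loosely on this exchange; a shift within the scatter, or a modest move toward weaker inhibition, is expected, a 1.6-fold higher number from compound 2 to compound 3 (0.21 log units; within the scatter). The estimate for compound 3 is 60000 nM, expected within 20000 nM to 150000 nM.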

Compound 3, concentration for total growth inhibition: 88200 nM
Beside the measured number, compound 3's estimate is 1.5-fold (0.17 log units) below it; low and high end bracket the measured number.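

In this assay, with the methyl held constant, the atom joining it to the aromatic carbon between two ring nitrogen atoms matters on its own: methylsulfanyl in place of the selenium group gives a 2.4-fold higher number from compound 2 to compound 3 (0.38 log units; beyond the scatter). Among these compounds, the earlier step changed methyl and selenium together, so this is the first reading of the sulfur-for-selenium exchange alone. Methyl in place of hydrogen on a sulfur gives an at least 1.1-fold lower number from compound 1 to compound 3 (0.05 log units; that floor lies within the scatter) and so cannot be read as a change. Compound 1 stands at a limit: the limit of > 100000 nM in this assay, at which 1 of the 3 values shown sits.

Open, on these data alone, is how a longer chain on the sulfur or selenium, or an amine on this aromatic carbon, would read. Also open, as far as these compounds go, is whether the selenium-to-sulfur gap holds with a group other than the benzylamino group on the shared core.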